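Fused-core aldehydes: aryl swap at the ring carbon

A few compounds are considered here, and "the series" means these few. Any claim that something is new, unique, unknown or untested is made for them only; others in the source may bear on it.

Measured so far:
Compound 1, `COc1ccc(-c2nc3sc(Cc4ccc(Cl)cc4)nn3c2C=O)cc1`, 5300 nM in a functional assay on L1210 cells (Mus musculus) for cytotoxicity, with a stated time of 48 h; a higher number here means a weaker inhibitor, a lower number a stronger inhibitor.
Compound 2, `Cc1ccc(-c2nc3sc(Cc4ccc(Cl)cc4)nn3c2C=O)cc1`, 23000 nM in this assay.
Compound 3, `O=Cc1c(-c2ccc(Cl)cc2Cl)nc2sc(Cc3ccc(Cl)cc3)nn12`, 82000 nM in this assay.

Compound 3 gives the highest number of the three. Its nearest neighbour is compound 2, a 3.6-fold higher number from compound 2 to compound 3 (0.55 log units; beyond the scatter); the furthest is compound 1, a 15-fold higher number from compound 1 to compound 3 (1.19 log units; beyond the scatter). Both steps lie beyond the scatter, so compound 3 is the weakest inhibitor in this set.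

Compound 4, `O=Cc1c(-c2ccc([N+](=O)[O-])cc2)nc2sc(Cc3ccc(Cl)cc3)nn12`, is still to be measured. It differs from compound 3 in one place: 4-nitrophenyl in place of 2,4-dichlorophenyl on an aromatic carbon.

For the measured compounds named here, no measured step carries a nitro group, so the change itself has no direct precedent. What the set does show is that replacing the 2,4-dichlorophenyl by a 4-methoxyphenyl or a 4-methylphenyl lowered the number, modestly in one case and by a large step in the other; those two steps are read in reverse for the present change. A 4-nitrophenyl again carries its single substituent in the 4-position, so a lower number than that of compound 3 is expected, of a size between the two steps seen, a 5.5-fold lower number from compound 3 to compound 4 (0.74 log units; beyond the scatter).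

Compound 4 is therefore estimated at 15000 nM in this assay, with a range from 4000 nM to 60000 nM.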

Compound 4, half-maximal inhibitory concentration: 15000 nM
Compound 4: the middle estimate sits on the measured number at the digits printed; measured number inside the range.
By their numbers in this assay, from the lowest: compound 1; then compounds 4 and 2 (each within the scatter of the next); then compound 3.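

In this assay the 4-nitrophenyl at this ring carbon gives a 5.5-fold lower number from compound 3 to compound 4 (0.74 log units; beyond the scatter) and so the drop from the 2,4-dichlorophenyl is not confined to the 4-methoxyphenyl and 4-methylphenyl groups seen earlier. Nitro and methyl are not separated at this position, with a 1.5-fold lower number from compound 2 to compound 4 (0.19 log units; within the scatter) as the step between them, whereas methoxy stays ahead of nitro, with a 2.8-fold higher number from compound 1 to compound 4 (0.45 log units; beyond the scatter) as the step, and this leaves compound 1 as the strongest inhibitor of the four. The data shown hold no measurement that bears on what lies behind this order.

Open, as far as these compounds go, is whether a plain 4-chlorophenyl would sit with compound 3 or with compound 4, which would show how much of the high number of compound 3 goes with the second chlorine of its 2,4-dichlorophenyl. Also open, from the compounds shown here alone, is where a 4-aminophenyl or a 4-carboxyphenyl would fall at this ring carbon, and whether the same order of aryl groups holds when a hydroxymethyl replaces the formyl group on the shared core.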